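The source may hold more compounds than are shown below. What is called first, only, known or untested is meant among the compounds shown, and "the series" means these compounds.

Compound 1 `CCCn1c(=O)n(CCC(N)=O)c(=O)c2[nH]cnc21` gives 31500 nM in an assay on Cerebral cortex for binding affinity to adenosine receptor A1 (Cavia porcellus), read by radioligand binding; on this read-out lower numbers stand for stronger inhibition and higher numbers for weaker inhibition. Compound 2 `CCCn1c(=O)n(C)c(=O)c2c1ncn2CCC(=O)O` reaches only a limit of this assay, > 200000 nM, one of the two values standing at the limit of > 200000 nM in this assay, at which 1 of the 2 values shown sits, so its place on the numbers shown is known only as a limit. Compound 3 `CCCn1c(=O)n(C)c(=O)c2c1ncn2CCN(C)C` differs from compound 2 by dimethylamino in place of carboxy on a saturated chain carbon, two bonds along the chain from an aromatic nitrogen. For the measured compounds named here, with no measured step of this kind to lean on, the expected step of an at least 3.3-fold lower number from compound 2 to compound 3 (0.52 log units; beyond the scatter) is taken as a move toward stronger inhibition, beyond the scatter but uncertain in size. Compound 3 is therefore estimated at 60000 nM, within 15000 nM to 200000 nM.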

Compound 3, inhibition constant: > 200000 nM
Compound 3: only a limit was reported (the forecaster's own chance of this, stated with the estimate: 30%); at least 3.3-fold (0.52 log units) between middle value and limit.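

For the compounds shown here, compound 2 and compound 3 both stand at a limit in this assay, so no step between them can be read: the limit of > 200000 nM in this assay, at which 2 of the 3 values shown sit. On these data alone, whether dimethylamino in place of carboxy changes the value at all remains open.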